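Aryl substituent swap from methyl to nitro, compound 4

The compounds below may be only part of what the source reports. "The series", "measured", "known", "first", "only" and "open" are said of these compounds alone.

The series shares one core and differs only in the group on the terminal six-membered aromatic ring of carbon only. Compound 1 `Clc1ccc(-c2csc(N/N=C/c3ccc(-n4ccnc4)cc3)n2)cc1` carries chloro, compound 2 `Brc1ccc(-c2csc(N/N=C/c3ccc(-n4ccnc4)cc3)n2)cc1` bromo, compound 3 `Cc1ccc(-c2csc(N/N=C/c3ccc(-n4ccnc4)cc3)n2)cc1` methyl. In an ADME assay on THP-1 cells (Homo sapiens) for cytotoxicity, read by MTT assay, tested at 50 ug/mL (a lower number here means less inhibition, a higher number more inhibition at the concentration tested (going by the name of the read-out)), compound 1 gives 32.1%, compound 2 gives 36.8% and compound 3 gives 36%. Compound 3 sits among the others within the scatter: a number 0.8 percentage points lower from compound 2 to compound 3 (within the scatter), a number 3.9 percentage points higher from compound 1 to compound 3 (within the scatter), and also a number 4.7 percentage points higher from compound 1 to compound 2 (within the scatter). For the measured compounds named here, nothing measured so far separates the three.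

Compound 4 `O=[N+]([O-])c1ccc(-c2csc(N/N=C/c3ccc(-n4ccnc4)cc3)n2)cc1` takes the next step: nitro in place of methyl on an aromatic carbon. All three measured steps change the same position and all stayed within the scatter, so they bear directly on this one; none of them, however, brings in a nitro, so the step is less well anchored. The expectation is a step of no change at the digits printed from compound 3 to compound 4 (within the scatter), that is, none beyond the scatter. Compound 4 is therefore estimated at 36% in this assay, with a range from 22% to 50%.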

Compound 4, a percentage reported as inhibition, at one concentration (the size of the read-out at that concentration, not a potency): 16.4%
Compound 4: middle estimate off by 19.6 percentage points, on the high side; the whole stated range lies above it.
By their numbers in this assay, from the lowest: compound 4; then compounds 1, 3 and 2 (each within the scatter of the next).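

This position on the terminal ring is not indifferent in this assay after all: nitro in place of methyl gives a clear step (a number 19.6 percentage points lower from compound 3 to compound 4 (beyond the scatter)), and the same shift appears against bromo (a number 20.4 percentage points lower from compound 2 to compound 4 (beyond the scatter)) and chloro (a number 15.7 percentage points lower from compound 1 to compound 4 (beyond the scatter)). Chloro, bromo and methyl stay within the scatter of one another, so nitro is the first group here to separate from the rest, and compound 4 reads lowest of the four, with all three steps beyond the scatter. No measurement at hand accounts for this drop.

On these data alone, whether the drop belongs to nitro alone remains open: an amine, a carboxylic acid or a nitrile on the same aromatic carbon would show whether other groups share it. As far as these compounds go, a reading at one concentration is not a potency, so how compound 4 compares at other concentrations also remains open.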